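The source may hold more compounds than are shown below. What is called first, only, known or untested is meant among the compounds shown, and "the series" means these compounds.

Measured compounds:
- compound 1 `O=C(Nc1cccc(-n2cc(-c3ccncc3)c(-c3ccc(Cl)c(O)c3)n2)c1)Nc1ccc(Cl)c(Cl)c1` gives 940 nM in a functional assay on A498 cells (Homo sapiens) for inhibition, read by sulforhodamine B assay, with a stated time of 48 h; on this read-out lower numbers stand for stronger inhibition and higher numbers for weaker inhibition
- compound 2 `COc1cc(-c2nn(-c3cccc(NC(=O)c4ccc(Cl)c(C(F)(F)F)c4)c3)cc2-c2ccncc2)ccc1Cl` gives 2700 nM in this assay
- compound 3 `COc1cc(-c2nn(-c3cccc(NC(=O)c4cccc(C(F)(F)F)c4)c3)cc2-c2ccncc2)ccc1Cl` gives 690 nM in this assay

Compound 3 has the lowest number of the three in this assay. Compound 1 is nearest, and the two lie within the scatter of each other, so no order between them can be read. Going by the values given here, compound 2 is furthest; the only single-place step in the set is a 3.9-fold lower number from compound 2 to compound 3 (0.59 log units; beyond the scatter), a modest one.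

Compound 4 `COc1cc(-c2nn(-c3cccc(NC(=O)Nc4cccc(C(F)(F)F)c4)c3)cc2-c2ccncc2)ccc1Cl` is not yet measured. It differs from compound 3 by (3-(trifluoromethyl)phenyl)amino in place of 3-(trifluoromethyl)phenyl on a carbonyl carbon.

No measured step bears on this change: the one shown step concerns chloro against hydrogen on an aromatic carbon, not the carbonyl carbon. Among the compounds with values here, compound 1 is the only measured compound that carries an amino group on its carbonyl carbon, but it differs from compound 3 in several places at once, so only its value can be compared, and compound 1 and compound 3 sit within the scatter of each other. On that basis no step beyond the scatter is expected in this assay for compound 4, in either direction. The expected step is a 1.2-fold higher number from compound 3 to compound 4 (0.06 log units; within the scatter). Compound 4 is estimated at 800 nM, with a range from 300 nM to 2200 nM.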

Compound 4, half-maximal inhibitory concentration: 960 nM
The estimate for compound 4 lay 1.2-fold (0.08 log units) below the measured number; low and high end bracket the measured number.
By their numbers in this assay, from the lowest: compounds 3, 1 and 4 (each within the scatter of the next); then compound 2.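

In this assay, the change from 3-(trifluoromethyl)phenyl to (3-(trifluoromethyl)phenyl)amino on the carbonyl carbon gives a 1.4-fold higher number from compound 3 to compound 4 (0.14 log units; within the scatter), so at this position the read-out does not separate the two groups, even though the entering group brings one nitrogen and one hydrogen-bond donor. Going by these compounds alone, the comparison with the chloro-bearing group gives a 2.8-fold lower number from compound 2 to compound 4 (0.45 log units; beyond the scatter), and together with a 3.9-fold lower number from compound 2 to compound 3 (0.59 log units; beyond the scatter) this places compound 2, the only one of these three compounds with 4-chloro-3-(trifluoromethyl)phenyl on the carbonyl carbon, at the high end with either chloro-free group. Nothing measured here explains either result.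

Still open is whether a chloro on the (3-(trifluoromethyl)phenyl)amino group would raise the number in the same way as on the group without the amino link, since the shown compounds offer no such single-place pair. On these data alone, it also remains open whether a methylene or an oxygen atom linking the carbonyl carbon to the 3-(trifluoromethyl)phenyl ring would read like the amino link.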